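A few compounds are considered here, and "the series" means these few. Any claim that something is new, unique, unknown or untested is made for them only; others in the source may bear on it.

Of the compounds shown here, three sharing one core have been tested so far. Compound 1 `CC1(C)C[C@H](O)C[C@](C)(CNc2ccccc2)C1` carries an unsubstituted aromatic ring; in an ADME assay on MDCK cells (Canis lupus familiaris) for cytotoxicity, read by MTT assay, with a stated time of 3 days (on this read-out lower numbers stand for higher toxicity in this test and higher numbers for lower toxicity in this test), compound 1 gives 37000 nM. Compound 2 `CC1(C)C[C@H](O)C[C@](C)(CNc2cccc(Cl)c2)C1` adds a chloro group to that ring, and in this assay compound 2 gives 9700 nM. Compound 3 `CC1(C)C[C@H](O)C[C@](C)(CNc2cc(F)cc(Cl)c2)C1` adds a fluoro group as well, and in this assay compound 3 gives 4400 nM.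

Compound 2 thus holds the second highest number of the three: compound 1 sits above it by a 3.8-fold lower number from compound 1 to compound 2 (0.58 log units; beyond the scatter) read backwards, while compound 3 sits below it by a 2.2-fold lower number from compound 2 to compound 3 (0.34 log units; beyond the scatter).

Compound 4 `CC1(C)C[C@H](O)C[C@](C)(CNc2cccc(C#N)c2)C1` differs from compound 2 in one place: cyano in place of chloro on an aromatic carbon.

Both measured steps concern a halogen entering in place of hydrogen, and each lowered the number: the step from compound 1 to compound 2 was a 3.8-fold lower number from compound 1 to compound 2 (0.58 log units; beyond the scatter), and the step from compound 2 to compound 3 was a 2.2-fold lower number from compound 2 to compound 3 (0.34 log units; beyond the scatter). Neither step covers a halogen leaving, nor a cyano group entering, so there is no direct guide here. With the chloro group gone, the number for compound 4 is expected to move back toward that of compound 1, though only modestly, giving an estimated step of a 1.6-fold higher number from compound 2 to compound 4 (0.22 log units; within the scatter). Compound 4 is therefore estimated at 16000 nM, expected to fall between 5500 nM and 45000 nM.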

Compound 4, half-maximal cytotoxic concentration: 46900 nM
For compound 4 the middle estimate is 2.9-fold (0.47 log units) below the measured one; measured number outside the range, above it.
By their numbers in this assay, from the lowest: compound 3; then compound 2; then compounds 1 and 4 (each within the scatter of the next).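

In this assay, the chloro group of compound 2 and the cyano group of compound 4 occupy the same place on the aromatic ring, yet the swap gives a 4.8-fold higher number from compound 2 to compound 4 (0.68 log units; beyond the scatter) and so reverses the fall seen when chloro entered. Set against the unsubstituted ring, cyano in place of hydrogen gives a 1.3-fold higher number from compound 1 to compound 4 (0.10 log units; within the scatter) and leaves no measurable change in this test, so a group at this position need not lower the number, as chloro did in compound 2. What separates chloro from cyano here cannot be explained, as no measurement of any property of these groups or compounds is available.

Still open, as far as these compounds go, is how other groups at this position would behave, such as a bromo group, a methoxy group, an amine or a carboxylic acid, and so whether chloro or cyano is the more typical case. From the compounds shown here alone, it is also open whether the further fall seen with the fluoro group in compound 3 would appear on a ring carrying cyano instead of chloro.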